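Weak antiproliferative thiophene carboxamides with a varied ring amine

The source may hold more compounds than are shown below. What is called first, only, known or untested is meant among the compounds shown, and "the series" means these compounds.

Measured compounds:
compound 1, `Cc1ccccc1CN1CCc2c(sc(NC(=O)c3ccccc3Cl)c2C(N)=O)C1`: > 50000 nM
compound 2, `Cc1ccc(C(=O)Nc2sc3c(c2C(N)=O)CCN(Cc2c(Cl)cccc2Cl)C3)cc1`: 47400 nM
compound 3, `NC(=O)c1c(NC(=O)c2cccc([N+](=O)[O-])c2)sc2c1CCN(Cc1ccc(Cl)cc1Cl)C2`: 33000 nM

All three were tested in a functional assay on HeLa cells (Homo sapiens) for antiproliferative activity, with a stated time of 24 h; a higher number here means a weaker inhibitor, a lower number a stronger inhibitor. Compound 1 gives only a limit there, > 50000 nM; this is the limit of the assay and not a number, as noted in the limit of > 50000 nM in this assay, at which 1 of the 3 values shown sits. Compound 2 gives 47400 nM and compound 3 gives 33000 nM, so the whole set sits at weak inhibition, and compound 1 stands at the weakest end, where the assay stops reporting a number.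

Compound 4, `NC(=O)c1c(NC(=O)c2ccccc2Cl)sc2c1CCN(C(=S)Nc1ccccc1Br)C2`, has not been measured. It differs from compound 1 at the amine nitrogen in the ring: a group of 10 heavy atoms (7 carbon, 1 nitrogen, 1 sulfur, 1 bromine; one six-membered aromatic ring of carbon only) in place of a group of 8 heavy atoms (8 carbon; one six-membered aromatic ring of carbon only), on an amine nitrogen in a ring. Among the measured compounds shown here, no step between measured compounds bears on this change. With every measured value at or near the upper edge of this assay, no shift beyond the scatter is expected, in either direction. Compound 4 is therefore estimated at 45000 nM, within 12000 nM to 100000 nM, which would mean an expected step of an at least 1.1-fold lower number from compound 1 to compound 4 (0.04 log units; that floor lies within the scatter) and a fair chance that this assay again reports only a limit.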

Compound 4, half-maximal inhibitory concentration: 24600 nM
The estimate for compound 4 lay 1.8-fold (0.26 log units) above the measured number; measured number inside the range.
By their numbers in this assay, from the lowest: compounds 4, 3 and 2 (each within the scatter of the next). At a limit, above all of these: compound 1.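

In this assay, the amine nitrogen in the ring carries a group with a hydrogen-bond donor and a hydrogen-bond acceptor in compound 4, which 2-methylbenzyl in compound 1 lacks, and compound 4 returns a number rather than a limit. This change gives an at least 2.0-fold lower number from compound 1 to compound 4 (0.30 log units; that floor lies within the scatter), so the compounds shown establish no gain beyond the scatter, though the true step could be larger. Compound 1 gives only a limit of the assay and not a number: the limit of > 50000 nM in this assay, at which 1 of the 4 values shown sits.

The compounds shown do not separate the contributions of the bromine, the sulfur and the nitrogen in the entering group. As far as these compounds go, it also remains open how a matching urea with oxygen in place of sulfur, an unsubstituted phenyl ring or a free ring amine would read at this position.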